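Compound 1 to compound 4: butyl for 4-bromophenyl

The source may hold more compounds than are shown below. What is called first, only, known or untested is meant among the compounds shown, and "the series" means these compounds.

In a functional assay on HeLa cells (Homo sapiens) for antiproliferative activity, read by MTT assay, with a stated time of 3 days (a lower number here means a stronger inhibitor, a higher number a weaker inhibitor), compound 1 (`O=C1c2ccccc2C(=O)N1C/C=C\Cn1cc(C#Cc2ccc(Br)cc2)c(=O)[nH]c1=O`) gives 87000 nM and compound 3 (`CCCCCC#Cc1cn(C/C=C/CN2C(=O)c3ccccc3C2=O)c(=O)[nH]c1=O`) gives 91000 nM, two numbers within the scatter of each other. Compound 2 (`CCCCCCCCC#Cc1cn(C/C=C/CN2C(=O)c3ccccc3C2=O)c(=O)[nH]c1=O`) gives > 100000 nM, which is a limit of the assay and not a number.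

Compound 4 (`CCCCC#Cc1cn(C/C=C\CN2C(=O)c3ccccc3C2=O)c(=O)[nH]c1=O`) has not yet been measured. It differs from compound 1 as follows: butyl in place of 4-bromophenyl on a triple-bonded carbon.

Among the compounds with values here, the only measured step is an at least 1.0-fold lower number from compound 2 to compound 3 (0.04 log units; that floor lies within the scatter), hydrogen in place of propyl on a saturated chain carbon, and its floor lies within the scatter. Within the data shown here, no measured step replaces 4-bromophenyl directly, so this step bears on the change only loosely. With compound 3 at 91000 nM, no step beyond the scatter is expected in this assay, in either direction.

The estimated change is a 1.0-fold lower number from compound 1 to compound 4 (0.01 log units; within the scatter). Compound 4 is expected at 85000 nM, with an estimated range of 40000 nM to 130000 nM.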

Compound 4, half-maximal inhibitory concentration: 33000 nM
Beside the measured number, compound 4's estimate is 2.6-fold (0.41 log units) above it; the measured number lies below the stated range.
By their numbers in this assay, from the lowest: compound 4; then compounds 1 and 3 (each within the scatter of the next). At a limit, above all of these: compound 2.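

In this assay, within the data shown here, the group on the triple-bonded carbon now moves the number beyond the scatter, which no earlier step showed: the step reads a 2.6-fold lower number from compound 1 to compound 4 (0.42 log units; beyond the scatter). An aromatic ring at this place is thus not required for the lower number, as butyl, with no ring and fewer heavy atoms than 4-bromophenyl, carries it. Nothing measured here accounts for this step.

Still open, from the compounds shown here alone, is whether a plain phenyl without bromine, a shorter or branched chain, or a chain ending in an amine or a carboxylic acid would take the number lower at this place. Among these compounds, also open is whether the same exchange gives a similar step with the other double-bond geometry, the one carried by compound 3.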